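The source may report more compounds than this note shows. Statements on the series, on what has been measured and on what is new or still open speak of the compounds shown alone.

Compound 1 `Cn1cccc1-c1cc(-c2ccc(Br)cc2)[nH]c(=O)c1C#N` gives > 100000 nM in a functional assay on SF-268 cells (Homo sapiens) for cytotoxicity, read by sulforhodamine B assay, with a stated time of 48 h; on this read-out higher numbers stand for weaker inhibition of growth and lower numbers for stronger inhibition of growth.
Compound 2 `COc1ccc(-c2cc(-c3cccn3C)c(C#N)c(=O)[nH]2)cc1OC` gives > 100000 nM.
Compound 3 `COc1ccc(-c2cc(-c3cccs3)[nH]c(=O)c2C#N)cc1` gives > 100000 nM.

Each of these three values is a limit of this assay, not a number. Compound 1 therefore stands nowhere on a scale of measured potency: it sits, with the other two, at the limit of > 100000 nM in this assay, at which 3 of the 3 values shown sit. The unmeasured compound 4 `Cn1cccc1-c1cc(-c2ccc(Br)cc2)n(C(=S)Nc2ccc(F)cc2)c(=O)c1C#N` differs from compound 1 by a group of 10 heavy atoms (7 carbon, 1 nitrogen, 1 fluorine, 1 sulfur; one six-membered aromatic ring of carbon only) in place of a hydrogen atom, on an aromatic nitrogen, that is, a group of 10 heavy atoms in place of a hydrogen atom, on an aromatic nitrogen. For the measured compounds named here, no pair of measured compounds differs in one place, so no measured step sets a scale for this change. The step from compound 1 to compound 4 is expected to be small, an at least 1.2-fold lower number from compound 1 to compound 4 (0.09 log units; that floor lies within the scatter), with a fair chance that only a limit is reported again. Compound 4 is estimated at 80000 nM, in the range 10000 nM to 300000 nM.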

Compound 4, concentration for 50% growth inhibition: 20400 nM
The estimate for compound 4 lay 3.9-fold (0.59 log units) above the measured number; measured number inside the range.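

Placing a substituent on the aromatic nitrogen gives the first reading in this assay that is a number and not a limit: the limit of > 100000 nM in this assay, at which 3 of the 4 values shown sit.

The group of 10 heavy atoms in place of the hydrogen atom brings an at least 4.9-fold lower number from compound 1 to compound 4 (0.69 log units; beyond the scatter), so growth inhibition becomes measurable with this nitrogen substituted. That step is only a floor, as the value of compound 1 is a limit.

From the compounds shown here alone, it stays open which part of the entering group carries the step: the sulfur, the fluorine or the aromatic ring. Also open, going by these compounds, is whether a methyl or acetyl group on this nitrogen, or the same group on the cores of compound 2 and compound 3, would do the same.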